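The source may hold more compounds than are shown below. What is called first, only, known or untested is meant among the compounds shown, and "the series" means these compounds.

Measured so far:
compound 1 `Cc1ccc(S(=O)(=O)/C=C/S(=O)(=O)CC2=NCCO2)cc1` — in a functional assay for inhibition, tested at 100 uM (a higher number here means more inhibition at the concentration tested (going by the name of the read-out), a lower number less inhibition), compound 1 gives 74.2%
compound 2 `O=S(=O)(CC1=NCCS1)c1c[nH]cc1S(=O)(=O)c1ccccc1` — in this assay compound 2 gives 34.6%

Compound 1 holds the higher of the two numbers; compound 2 sits well below it, a gap beyond the usual scatter. Among the measured compounds shown here, compound 1 and compound 2 differ at several places, so no single-change step between measured compounds is available, and the two values show only where each stands.

The step followed here leads from compound 1 to compound 3 `O=S(=O)(/C=C/S(=O)(=O)c1ccccc1)CC1=NCCO1`, which has not yet been measured in this assay. The difference: hydrogen in place of methyl on an aromatic carbon. The group that leaves is a methyl, one heavy atom, no ring, no donors or acceptors; what enters is a hydrogen atom on an aromatic carbon of the six-membered aromatic ring of carbon only. Nothing in the measured pair bears directly on this change. For a change of this size the expected step in this assay is small, most likely a modest loss of inhibition or none beyond the scatter, and a number 7.2 percentage points lower from compound 1 to compound 3 (within the scatter) is the step expected. Compound 3 is estimated at 67%, in the range 50% to 84%.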

Compound 3, a percentage reported as inhibition, at one concentration (the size of the read-out at that concentration, not a potency): 82.1%
Estimate against measurement, compound 3: 15.1 percentage points below, within the range that was stated.
By their numbers in this assay, from the lowest: compound 2; then compounds 1 and 3 (each within the scatter of the next).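

In this assay, among the compounds shown here, compound 3 gives 82.1%, and this provides the first single-place comparison: a number 7.9 percentage points higher from compound 1 to compound 3 (within the scatter), with 4-methylphenyl replaced by phenyl. The assay therefore does not separate methyl from hydrogen on this aromatic carbon, para to a large group, and at the concentration tested the methyl is not required for inhibition at the level seen for these two compounds. No measurement available here gives a reason for this result.

With only methyl and hydrogen shown at this position, it remains open whether a larger or different substituent, such as an amine, a carboxylic acid or a longer chain, would also leave the number within the scatter or move it beyond. Compound 2 differs from both compound 1 and compound 3 in several places, so its value cannot be assigned to any one change, and the contributions of the other parts of the shared structure cannot be read from these compounds.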